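A New Aryl Group on the Ring Nitrogen

The source may report more compounds than this note shows. Statements on the series, on what has been measured and on what is new or still open speak of the compounds shown alone.

Measured so far:
compound 1, `Cc1nc(-c2ccccc2)c(C(=O)N2CCN(c3ccc(Cl)c(Cl)c3)CC2)o1`, 124 nM
compound 2, `CC(C)(C)c1nc(-c2ccccc2F)c(C(=O)N2CCN(c3cccc(Cl)c3)CC2)o1`, > 1000 nM

Within the data shown here, compound 1 is the only compound with a number in a functional assay on HL-60 cells (Homo sapiens) for inhibition, read by MTT assay, with a stated time of 72 h; a lower number here means a stronger inhibitor, a higher number a weaker inhibitor. Compound 2 gives just a limit there, (the limit of > 1000 nM in this assay, at which 1 of the 2 values shown sits), and not a number. Compound 3, `C=C(C)c1ccc(N2CCN(C(=O)c3oc(C)nc3-c3ccccc3)CC2)cc1`, is still unmeasured. It differs from compound 1 in one place: 4-(1-methylethenyl)phenyl in place of 3,4-dichlorophenyl on an amine nitrogen in a ring. Among the measured compounds shown here, no measured pair separated by exactly this change exists, so the expected step is a moderate weakening, though it could also stay within the scatter. Compound 3 is expected to give 300 nM, within 80 nM to 1500 nM. This amounts to an expected step of a 2.4-fold higher number from compound 1 to compound 3 (0.38 log units; beyond the scatter).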

Compound 3, half-maximal inhibitory concentration: "not active" (no number reported)
Compound 3 has no reported number here; no gap can be computed for the estimate.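

Among these compounds, compound 3 is reported as "not active" with no number in this assay, so no step from compound 1 to compound 3 can be read. Nothing shown bears on this result. As far as these compounds go, how far 4-(1-methylethenyl)phenyl in place of 3,4-dichlorophenyl shifts the value remains open.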